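Bromo to chloro exchange, compound 2 to compound 3

The source may report more compounds than this note shows. Statements on the series, on what has been measured and on what is new or still open speak of the compounds shown alone.

Compound 1 `COc1ccc(O)c(/C=N/c2ccc(OCc3ccccc3)cc2)c1` and compound 2 `Oc1ccc(Br)cc1/C=N/c1ccc(OCc2ccccc2)cc1` share one core and differ by bromo in place of methoxy on an aromatic carbon. In a functional assay, with a stated time of 30 min (a higher number here means a weaker inhibitor, a lower number a stronger inhibitor), compound 1 gives only a limit, > 200000 nM. Compound 2 likewise gives only a limit in this assay, > 200000 nM. The step that the two limits leave unreadable from compound 1 to compound 2 is therefore not readable, and the whole evidence is the limit of > 200000 nM in this assay, at which 2 of the 2 values shown sit. Compound 2 thus stands at the limit of this assay, without a number of its own.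

Compound 3 `Oc1ccc(Cl)cc1/C=N/c1ccc(OCc2ccccc2)cc1` differs from compound 2 as follows: chloro in place of bromo on an aromatic carbon. Within the data shown here, the one measured step is of unreadable size and does not show how a halogen exchange acts here, so no measured step bears on the change at hand. Bromo and chloro enter the same place, para to the hydroxy group, and there is no reason in the data for a readable shift. The step that the limit leaves unreadable from compound 2 to compound 3 is estimated as none beyond the scatter. Compound 3 is expected to give 300000 nM in this assay, within the range 100000 nM to 1000000 nM, most likely again reported only as a limit.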

Compound 3, half-maximal inhibitory concentration: > 200000 nM
Compound 3: only a limit was reported; the forecaster's own chance of this, stated with the estimate: 85%; the middle value is on the limit's open side.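

Compound 3 gives > 200000 nM in this assay as a limit and not a number. Among these compounds, no step among compound 1, compound 2 and compound 3 can be read, and the evidence is only this: the limit of > 200000 nM in this assay, at which 3 of the 3 values shown sit. The compounds shown leave open whether exchanging methoxy, bromo and chloro changes inhibition at all.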